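A Third Methoxy Group on the Ester Ring

The source may report more compounds than this note shows. Statements on the series, on what has been measured and on what is new or still open speak of the compounds shown alone.

compound 1 `COC(=O)/C(=C\c1ccc(O)cc1)Sc1ccnc2cc(Cl)ccc12` gives 4310 nM in a functional assay on HL-60 cells (Homo sapiens) for cytotoxicity, read by MTT assay, with a stated time of 24 h; on this read-out higher numbers stand for weaker inhibition and lower numbers for stronger inhibition
compound 2 `COC(=O)/C(=C\c1ccc(OC(=O)c2cc(OC)cc(OC)c2)cc1)Sc1ccnc2cc(Cl)ccc12` gives 19000 nM in this assay
compound 3 `COC(=O)/C(=C\c1ccc(OC(=O)c2cc(OCc3ccccc3)c(OCc3ccccc3)c(OCc3ccccc3)c2)cc1)Sc1ccnc2cc(Cl)ccc12` reaches only a limit, > 100000 nM, in this assay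

Compound 2 stands highest of the two numbers given in this assay; the nearest is compound 1, and the difference between them is a 4.4-fold higher number from compound 1 to compound 2 (0.64 log units; beyond the scatter). Compound 3, in a sentence of its own, shows no number but a limit, (the limit of > 100000 nM in this assay, at which 1 of the 3 values shown sits). Compound 4 `COC(=O)/C(=C\c1ccc(OC(=O)c2cc(OC)cc(OC)c2OC)cc1)Sc1ccnc2cc(Cl)ccc12` differs from compound 2 by methoxy in place of hydrogen on an aromatic carbon. Going by the values given here, the only measured step that bears on this change is the one from compound 1 to compound 2, where a (3,5-dimethoxyphenyl)carbonyl group in place of hydrogen gave a modest rise of the number; the further enlargement seen in compound 3 ends at the limit. A single added methoxy is a smaller change than either, so the expected shift in this assay is small, upward if anything, a 1.4-fold higher number from compound 2 to compound 4 (0.14 log units; within the scatter). Compound 4 is therefore estimated at 26000 nM, within a range from 9000 nM to 80000 nM.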

Compound 4, half-maximal inhibitory concentration: 10700 nM
Estimate against measurement, compound 4: 2.4-fold (0.39 log units) above; the range from low to high includes it.
By their numbers in this assay, from the lowest: compound 1; then compounds 4 and 2 (each within the scatter of the next). At a limit, above all of these: compound 3.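

The change from 3,5-dimethoxyphenyl to 2,3,5-trimethoxyphenyl gives a 1.8-fold lower number from compound 2 to compound 4 (0.25 log units; within the scatter) and so does not separate the two compounds in this assay. Where the whole (3,5-dimethoxyphenyl)carbonyl group gave a 4.4-fold higher number from compound 1 to compound 2 (0.64 log units; beyond the scatter) and moved the number beyond the scatter, one further methoxy on that ring, ortho to a large group, ortho to a methoxy group and para to a methoxy group, leaves no shift that can be read. Nothing among the data shown gives a reason for this result.

As far as these compounds go, it remains open whether this position is as undemanding for other groups, such as a hydroxyl, an amine or a longer chain like ethoxy, or whether the result belongs to methoxy alone. Also open, from the compounds shown here alone, is whether an amide in place of the ester linking this ring to the core would leave the picture the same.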